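The source may report more compounds than this note shows. Statements on the series, on what has been measured and on what is new or still open speak of the compounds shown alone.

In a functional assay on MCF7 cells (Homo sapiens) for inhibition (on this read-out lower numbers stand for stronger inhibition and higher numbers for weaker inhibition), compound 1 `Cc1ccc2nc(N/N=C/c3cccnc3Nc3ccccc3)sc2c1` gives 1690 nM and sits level, within the scatter, with compound 2 `N=C(N)N/N=C/c1cn(-c2nc3ccc(Oc4ccc(F)cc4)cc3s2)nc1-c1ccccc1` at 2230 nM on this read-out. Compound 3 `O=C(CSc1nc2ccc(NC(=O)CCl)cc2s1)NCc1ccccc1` shows 4200 nM as a higher number, beyond the scatter from compound 1. Compound 4 `Cc1ccc2nc(N/N=C/c3cccnc3Nc3ccc(Cl)cc3)sc2c1` differs from compound 1 by one change, chloro in place of hydrogen on an aromatic carbon with phenyl becoming 4-chlorophenyl: chloro in place of hydrogen on an aromatic carbon, para to a large group. No measured pair among these compounds shows what this swap does, so the expectation stays close to compound 1 at 1690 nM with a small shift toward stronger inhibition, none beyond the scatter. The estimated step of a 1.3-fold lower number from compound 1 to compound 4 (0.11 log units; within the scatter) stays that small. Compound 4 is expected at 1300 nM with a likely range from 500 nM to 3300 nM on this read-out.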

Compound 4, half-maximal inhibitory concentration: 1030 nM
Estimate against measurement, compound 4: 1.3-fold (0.10 log units) above; low and high end bracket the measured number.
By their numbers in this assay, from the lowest: compounds 4, 1, 2 and 3 (each within the scatter of the next, the first and the last beyond it).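

In this assay, the change from phenyl to 4-chlorophenyl gives a 1.6-fold lower number from compound 1 to compound 4 (0.22 log units; within the scatter), so compound 1 and compound 4 read as level. Among these compounds, this is the first pair here that differs in one place, and it shows that a chlorine atom on this aromatic carbon, para to a large group, leaves the read-out within the usual scatter. No supporting measurement offers any explanation of this result. Going by these compounds, whether a methoxy group or an amine at the same place would also stay level remains open.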